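Chloro-to-hydrogen step on the amide-bearing ring

This account rests on a few compounds, and the source may have more. Where it says the series, first, only, none or still open, it means among the compounds named here.

Measured so far:
Compound 1 `O=C(Nc1ccc([N+](=O)[O-])cc1)c1cc(Cl)ccc1O` gives 127 10^-6 cm/s in an ADME assay for permeability, using PAMPA; a lower number here means that the compound crosses the layer more slowly, a higher number that the compound crosses the layer faster.
Compound 2 `O=C(Nc1ccc([N+](=O)[O-])c(Cl)c1)c1cc(Cl)ccc1O` gives 68 10^-6 cm/s in this assay.
For compound 3 `O=C(Nc1ccc(F)c(Cl)c1)c1cc(Cl)ccc1O` the result in this assay is "not determined" (no result reported).

One structural change appears twice in this set. Between the two measured compounds it is hydrogen in place of chloro on an aromatic carbon, and the step it made is a 1.9-fold higher number from compound 2 to compound 1 (0.27 log units; within the scatter). The same kind of change, (hydrogen in place of chloro on an aromatic carbon), leads from compound 3 to compound 4 `O=C(Nc1ccc(F)cc1)c1cc(Cl)ccc1O`. The two settings are not identical: in compound 2 the chloro that leaves is ortho to a nitro group, whereas in compound 3 it is ortho to a fluoro group. The cores of compound 2 and compound 3 themselves differ by fluoro in place of nitro on an aromatic carbon.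

Since compound 3 has no number in this assay, the step to compound 4 cannot be anchored on a measured starting point. The step from compound 3 to compound 4 in this assay is expected to be of about the same size as the earlier one, small and within the scatter, an expectation that rests on a 1.9-fold higher number from compound 2 to compound 1 (0.27 log units; within the scatter). Compound 4 is accordingly estimated to give 120 10^-6 cm/s in this assay, with a plausible range from 60 10^-6 cm/s to 230 10^-6 cm/s, guided by compound 1 at 127 10^-6 cm/s.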

Compound 4, apparent permeability: 391 10^-6 cm/s
Beside the measured number, compound 4's estimate is 3.3-fold (0.51 log units) below it; the measured number lies above the stated range.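

In this assay, within the data shown here, the one readable step that reaches compound 4 is a 3.1-fold higher number from compound 1 to compound 4 (0.49 log units; beyond the scatter) and it comes with fluoro in place of nitro on an aromatic carbon, whereas the chloro-to-hydrogen change gave only a 1.9-fold higher number from compound 2 to compound 1 (0.27 log units; within the scatter) on the nitro-bearing core. On these data alone, the step from compound 3 to compound 4 cannot be read, so the chloro-to-hydrogen change remains untested on the fluoro-bearing core, and the high number for compound 4 shows neither that this change carries over from one core to the other nor that it fails to. Nothing measured here accounts for the size of either step.

With only nitro and fluoro shown at that place on the ring, it remains open whether an amine or a carboxylic acid there would sit nearer compound 1 or compound 4 in this assay. Also open, as far as these compounds go, is how the chloro-to-hydrogen change behaves on any core other than that of compound 2.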